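The compounds below may be only part of what the source reports. "The series", "measured", "known", "first", "only" and "open" are said of these compounds alone.

Compound 1 `CC(O)c1cc(-c2ccccc2)c2ccc(OCc3cccc(C4(O)CCOCC4)c3)cc2c1` gives 520 nM in an assay on isolated protein with Polyunsaturated fatty acid 5-lipoxygenase (Homo sapiens) as the target; a higher number here means a weaker inhibitor, a lower number a stronger inhibitor. Compound 2 `COC(=O)c1cc(-c2ccccc2)c2ccc(OCc3cccc(C4(O)CCOCC4)c3)cc2c1` gives 70 nM. Compound 3 `N#Cc1cc(-c2ccccc2)c2ccc(OCc3cccc(C4(O)CCOCC4)c3)cc2c1` gives 120 nM.

Compound 3 stands second highest of the three numbers: its nearest neighbour is compound 2, with a 1.7-fold higher number from compound 2 to compound 3 (0.23 log units; within the scatter), and its furthest is compound 1, with a 4.3-fold lower number from compound 1 to compound 3 (0.64 log units; beyond the scatter). Compound 4 `Cn1nnc(-c2cc(-c3ccccc3)c3ccc(OCc4cccc(C5(O)CCOCC5)c4)cc3c2)n1` differs from compound 3 by 2-methyl-2H-tetrazol-5-yl in place of cyano on an aromatic carbon. For the measured compounds named here, no measured step exchanges the nitrile for a ring. Going by the values given here, the steps that bear on it are a 7.4-fold lower number from compound 1 to compound 2 (0.87 log units; beyond the scatter) and a 4.3-fold lower number from compound 1 to compound 3 (0.64 log units; beyond the scatter), both modest, whereas the two acceptor-bearing groups gave numbers within the scatter of each other. Compound 4 is therefore expected to land close to compound 3, with no step beyond the scatter, estimated at 100 nM within 40 nM to 300 nM, meaning a 1.2-fold lower number from compound 3 to compound 4 (0.08 log units; within the scatter).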

Compound 4, half-maximal inhibitory concentration: 120 nM
For compound 4 the middle estimate is 1.2-fold (0.08 log units) below the measured one; measured number inside the range.
By their numbers in this assay, from the lowest: compounds 2, 3 and 4 (each within the scatter of the next); then compound 1.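

In this assay this aromatic carbon accepts a five-membered aromatic ring with 4 hetero atoms in place of a nitrile, and 2-methyl-2H-tetrazol-5-yl, with six heavy atoms against two for cyano, reads the same within the scatter (no change at the digits printed from compound 3 to compound 4 (within the scatter)). It also stays within the scatter of methoxycarbonyl (a 1.7-fold higher number from compound 2 to compound 4 (0.23 log units; within the scatter)). The gain over 1-hydroxyethyl therefore extends to a third group (a 4.3-fold lower number from compound 1 to compound 4 (0.64 log units; beyond the scatter)), and no measurement given here accounts for it.

Still open, from the compounds shown here alone, is whether a carboxylic acid or a primary amide on this carbon would group with compounds 2, 3 and 4 or with compound 1. Also open, going by these compounds, is what the ring's methyl contributes, which the unmethylated tetrazole would test.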